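Urea series: methyl position shift on the aniline ring

The source may report more compounds than this note shows. Statements on the series, on what has been measured and on what is new or still open speak of the compounds shown alone.

Measured compounds in a functional assay on PC-9 cells (Homo sapiens) for inhibition, read by MTT assay, with a stated time of 48 h, tested at 10 uM; on this read-out lower numbers stand for less inhibition and higher numbers for more inhibition at the one concentration tested (going by the name of the read-out):
compound 1, `COc1cc(NC(=O)Nc2cc(Nc3ccc(OC)c(C)c3)ncn2)cc(OC)c1`, 62%
compound 2, `COc1cc(NC(=O)Nc2cc(Nc3cc(Br)ccc3OC)ncn2)cc(OC)c1`, 82.5%
compound 3, `COc1cc(NC(=O)Nc2cc(Nc3ccc(C)c(F)c3)ncn2)cc(OC)c1`, 77.5%

Compound 3 stands second highest of the three numbers; its nearest neighbour is compound 2, whose value lies within the scatter of it, and its furthest is compound 1, which it exceeds beyond the scatter.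

The step to compound 4, `COc1cc(NC(=O)Nc2cc(Nc3cc(C)cc(F)c3)ncn2)cc(OC)c1`, keeps the same atoms joined differently: 3-fluoro-5-methylphenyl in place of 3-fluoro-4-methylphenyl on a nitrogen on an aromatic ring. Among the measured compounds shown here, no measured step moves a methyl group around the ring; the steps that involve the same nitrogen are a number 15.5 percentage points higher from compound 1 to compound 3 (beyond the scatter) and a number 20.5 percentage points higher from compound 1 to compound 2 (beyond the scatter), both modest, while a number 5 percentage points lower from compound 2 to compound 3 (within the scatter) lies within the scatter. All three groups that carry a substituent pattern other than that of compound 1 sit close together, so a change in this assay of no more than the scatter is expected from compound 3 to compound 4, a number 2.5 percentage points lower from compound 3 to compound 4 (within the scatter). Compound 4 is estimated at 75%, with a range of 60% to 88%.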

Compound 4, a percentage reported as inhibition, at one concentration (the size of the read-out at that concentration, not a potency): 64.5%
Estimate against measurement, compound 4: 10.5 percentage points above, and the stated range covers the measured number.
By their numbers in this assay, from the lowest: compounds 1 and 4 (each within the scatter of the next); then compounds 3 and 2 (each within the scatter of the next).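

In this assay, the two groups hold the same atoms, yet 3-fluoro-5-methylphenyl in place of 3-fluoro-4-methylphenyl on a nitrogen on an aromatic ring gives a number 13 percentage points lower from compound 3 to compound 4 (beyond the scatter), so the arrangement of the substituents on this ring counts, and not only which substituents it carries. The same group also parts from 5-bromo-2-methoxyphenyl, with a number 18 percentage points lower from compound 2 to compound 4 (beyond the scatter), but not from 4-methoxy-3-methylphenyl, with a number 2.5 percentage points higher from compound 1 to compound 4 (within the scatter), which places compound 4 with compound 1 rather than with compound 2 or compound 3. Nothing measured here accounts for the gap between the two isomers.

From the compounds shown here alone, whether the number in this assay is higher, lower or level with other groups in the 3-fluoro-5-methylphenyl pattern stays open, for instance an amine or an ethyl group in the place of the methyl. Going by these compounds, these are also readings at one concentration, so how the compounds compare in potency remains unknown.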